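The source may hold more compounds than are shown below. What is called first, only, known or untested is meant among the compounds shown, and "the series" means these compounds.

The study concerns compounds 1 and 2, which were measured, and compound 3, which awaits its number. Compound 1 `CNC(=O)N1CCCc2ccc(NC(=O)c3cccc(-c4cn[nH]c4)c3)cc21` carries an unsubstituted five-membered ring bearing two nitrogens on its benzamide, and in a functional assay on MV4-11 cells (Homo sapiens) for antiproliferative activity, with a stated time of 6 days, tested at 1.56 uM (a lower number here means a weaker effect, a higher number a stronger effect of the compound at the concentration tested), compound 1 gives 27.9%. Compound 2 `CNC(=O)N1CCCc2ccc(NC(=O)c3ccc(-c4ccncc4)cc3)cc21` carries a six-membered nitrogen ring in place of that group, and in this assay compound 2 gives 37.6%. Compound 1 thus stands at the lower of the two numbers available, but the gap to compound 2 lies within the scatter of such measurements, so the two cannot be told apart on inhibition.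

Compound 3 `CNC(=O)N1CCCc2ccc(NC(=O)c3cccc(-c4cnn(S(C)(=O)=O)c4)c3)cc21` differs from compound 1 by a single change, (methylsulfonyl in place of hydrogen on an aromatic nitrogen). Going by the values given here, no pair of measured compounds differs in one place, so there is no measured step from which to read the weight of such a change in this assay. With only the two numbers above to go on, the writer expects the step from compound 1 to compound 3 to be small, most likely none beyond the scatter, and the expected step is a number 2.9 percentage points lower from compound 1 to compound 3 (within the scatter). Compound 3 is therefore estimated to give 25% in this assay, with an expected range from 8% to 45%, pending the measurement.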

Compound 3, a percentage reported as inhibition, at one concentration (the size of the read-out at that concentration, not a potency): 1.6%
Beside the measured number, compound 3's estimate is 23.4 percentage points above it; the whole stated range lies above it.
By their numbers in this assay, from the lowest: compound 3; then compounds 1 and 2 (each within the scatter of the next).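

In this assay, going by these compounds alone, methylsulfonyl in place of hydrogen on the aromatic nitrogen of the five-membered ring gives a number 26.3 percentage points lower from compound 1 to compound 3 (beyond the scatter), and this is the first step between compounds differing in one place. It shows that this nitrogen does not tolerate every change: the earlier pair of compounds differed in more than one place and could say nothing about this position, whereas a single substitution here moves the read-out beyond the scatter. The compounds shown offer no independent data on why this substitution has this effect.

As far as these compounds go, it remains open whether the step belongs to methylsulfonyl in particular or to any group that replaces the hydrogen on that nitrogen, a question that a plain methyl, an acetyl or a longer chain ending in an amine at the same place would help to settle. Also open, from the compounds shown here alone, is how the step translates into potency, as the read-out is the size of the inhibition at one concentration and a full concentration series on compound 1 and compound 3 would be needed to tell.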